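This account rests on a few compounds, and the source may have more. Where it says the series, first, only, none or still open, it means among the compounds named here.

Of the compounds shown here, three have been measured in a functional assay on A549 cells (Homo sapiens) for antiproliferative activity, read by sulforhodamine B assay, with a stated time of 3 days; on this read-out higher numbers stand for an effect only at larger amounts of compound and lower numbers for an effect already at smaller amounts. Compound 1 `CCCOC1=C(CCC)C(=O)/C(=C(O)/C=C/c2ccccc2)C(=O)C1(CCC)CCC` gives 1.9 uM. Compound 2 `CCCC1=C(OC)C(CCC)(CCC)C(=O)/C(=C(O)\C=C\c2ccc(I)cc2)C1=O` gives 1.4 uM, and compound 3 `CCCCC1=C(OC)C(CCCC)(CCCC)C(=O)/C(=C(O)\C=C\c2ccccc2)C1=O` gives 6.4 uM. Compound 1 therefore stands second highest of the three: its gap to compound 2 lies within the scatter of this assay, while compound 3 sits beyond the scatter with the higher number. Compound 4 `CCCC1=C(OC)C(CCC)(CCC)C(=O)/C(=C(O)\C=C\c2ccccc2)C1=O` has not yet been measured. It differs from compound 1 in one place: hydrogen in place of ethyl on a saturated chain carbon bound to an oxygen on an unsaturated carbon, so the propoxy becomes a methoxy. Within the data shown here, no pair of measured compounds isolates this change, and compound 3 carries both a methoxy and longer chains, so it cannot settle the point. The expected change is a 1.3-fold higher number from compound 1 to compound 4 (0.12 log units; within the scatter), small and in no direction beyond the scatter. Compound 4 is estimated at 2.5 uM, between 1 uM and 6 uM.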

Compound 4, concentration for half-maximal effect: 3.6 uM
Compound 4: middle estimate off by 1.4-fold (0.16 log units), on the low side; low and high end bracket the measured number.
By their numbers in this assay, from the lowest: compounds 2, 1, 4 and 3 (each within the scatter of the next, the first and the last beyond it).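

In this assay, hydrogen in place of ethyl, which turns propoxy into methoxy, gives a 1.9-fold higher number from compound 1 to compound 4 (0.28 log units; within the scatter), so this chain can be shortened without a measurable loss. Among these compounds, by contrast, hydrogen in place of iodo on an aromatic carbon gives a 2.6-fold higher number from compound 2 to compound 4 (0.41 log units; beyond the scatter), the one single change here that clears the scatter. No measurement at hand explains either step. Still open, as far as these compounds go, is how an amine or a fluoro on that aromatic carbon would compare with iodo. From the compounds shown here alone, a butoxy or a free hydroxyl in place of the propoxy also remains untested in these compounds, as does iodo combined with propoxy.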